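A few compounds are considered here, and "the series" means these few. Any claim that something is new, unique, unknown or untested is made for them only; others in the source may bear on it.

The compounds measured so far, each in an assay on isolated protein for inhibition of DNA nucleotidylexotransferase (Homo sapiens), read by scintillation counting, with a stated time of 10 min; on this read-out lower numbers stand for stronger inhibition and higher numbers for weaker inhibition:

Compound 1, `C/C=C/n1cc(/C=C/C(=O)CC(=O)C(=O)OCC)c2ccccc21`, gives > 40 uM, which is a limit of this assay and not a number.
Compound 2, `CCOC(=O)C(=O)CC(=O)/C=C/c1cn(-c2ccc(Cl)cc2)c2ccccc12`, gives > 40 uM, likewise a limit.
Compound 3, `CCOC(=O)C(=O)CC(=O)/C=C/c1cn(Cc2ccc(OC)cc2)c2ccccc12`, gives > 40 uM, again a limit.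

Compound 3 therefore stands at the limit together with the other two; nothing in the numbers separates it from them, as the limit of > 40 uM in this assay, at which 3 of the 3 values shown sit, shows. The unmeasured compound 4 is `CCOC(=O)C(=O)CC(=O)/C=C/c1cn(CC(=O)N2CCOCC2)c2ccccc12`. It differs from compound 3 in one place: (morpholin-4-yl)carbonyl in place of 4-methoxyphenyl on a saturated chain carbon bound to an aromatic nitrogen. Among the measured compounds shown here, the steps that bear on the same position are a step that the two limits leave unreadable from compound 1 to compound 3 and a step that the two limits leave unreadable from compound 2 to compound 3, and the related step that the two limits leave unreadable from compound 1 to compound 2, none of which can be read in size, since all three values are limits. Three different groups on the aromatic nitrogen have left this assay at its limit, so a fourth group at the same position is expected to do the same, and the step that the limit leaves unreadable from compound 3 to compound 4 is expected to be none beyond the scatter. Compound 4 is estimated at 60 uM, most likely reported as a limit, with a range from 20 uM to 200 uM.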

Compound 4, concentration for 50% inhibition: > 40 uM
Compound 4 gave a limit, no number (the forecaster's own chance of this, stated with the estimate: 80%); the middle value lies beyond the limit too.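

In this assay compound 4 gives > 40 uM, which is a limit and not a number. No step linking compound 4 to compound 1, compound 2 or compound 3 can be read in size, and all four compounds share one limit: the limit of > 40 uM in this assay, at which 4 of the 4 values shown sit.

The compounds shown leave open whether any group on the aromatic nitrogen gives a readable inhibition in this assay, and how far these four compounds differ, if they differ at all.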